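The compounds below may be only part of what the source reports. "The series", "measured", "known", "first", "only" and "open" are said of these compounds alone.

Measured so far in a functional assay on HBL-100 cells (Homo sapiens) for inhibition, read by sulforhodamine B assay, with a stated time of 48 h; a higher number here means a weaker inhibitor of growth, a lower number a stronger inhibitor of growth
- compound 1 `CCOC(=[Se])Nc1ccc2c(C)cc(=O)oc2c1` - > 100000 nM (a limit of the assay, not a number)
- compound 2 `CCCCNC(=[Se])Nc1ccc2c(C)cc(=O)oc2c1` - 2300 nM

Among the measured compounds shown here, compound 2 holds the only true number. Compound 3 `Cc1cc(=O)oc2cc(NC(=[Se])Nc3ccccc3)ccc12` has phenyl in place of butyl on an amine nitrogen. For the measured compounds named here, the one measured step, an at least 43-fold lower number from compound 1 to compound 2 (1.63 log units; beyond the scatter), is large and beyond the scatter, but it replaced ethoxy. On these data alone, compound 3 keeps the amine nitrogen brought in by that step, so no step beyond the scatter is expected in this assay, and the direction stays open. The expected change is a 1.2-fold lower number from compound 2 to compound 3 (0.06 log units; within the scatter). For compound 3 the estimated value is 2000 nM, with an expected range of 500 nM to 10000 nM.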

Compound 3, concentration for 50% growth inhibition: 28000 nM
The estimate for compound 3 lay 14-fold (1.15 log units) below the measured number; the measured number lies above the stated range.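

In this assay the group on the amine nitrogen is far from interchangeable, and phenyl in place of butyl gives weaker growth inhibition (a 12-fold higher number from compound 2 to compound 3 (1.09 log units; beyond the scatter)). Anilino in place of ethoxy still leaves a gain (an at least 3.5-fold lower number from compound 1 to compound 3 (0.55 log units; beyond the scatter)), so only part of the gain seen with butylamino survives on the aromatic group.

On these data alone, whether a longer chain, a cyclohexyl or a benzyl group on that nitrogen matches butyl stays open. The true size of the anilino gain also stays open, since compound 1 gives a limit and not a number: the limit of > 100000 nM in this assay, at which 1 of the 3 values shown sits.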